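The source may hold more compounds than are shown below. What is called first, only, known or untested is meant among the compounds shown, and "the series" means these compounds.

Working notes on the series. Of the compounds shown here, two on a shared core have numbers so far: compound 1 `COC(=O)C1=C(C)NC(c2nccs2)=NC1(C)c1ccc(F)cc1Cl` and compound 2 `COC(=O)C1=C(CN2CCNCC2)NC(c2nccs2)=NC1(C)c1ccc(F)cc1`. Going by the values given here, they differ at more than one place, so no single step links them. In a physicochemical assay for solubility, read by HPLC, in phosphate buffer, at pH 6.5 (on this read-out lower numbers stand for lower solubility and higher numbers for higher solubility), compound 1 gives 18 ug/mL. In this assay compound 2 gives 250 ug/mL, the highest of the two numbers; its nearest neighbour, compound 1, stands well below it, a gap beyond the scatter.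

Compound 3 `COC(=O)C1=C(COC2CCOC2)NC(c2nccs2)=NC1(C)c1ccc(F)cc1` is not yet measured in this assay. It is compound 2 with one change: (oxolan-3-yl)oxy in place of piperazin-1-yl on a saturated chain carbon bound to a double-bonded ring carbon. The piperazin-1-yl that leaves carries 1 hydrogen-bond donor; the (oxolan-3-yl)oxy that enters carries 0 hydrogen-bond donors and 2 hydrogen-bond acceptors. Among the compounds with values here, no measured step matches this exchange, so the direction rests on judgement only.

The step from compound 2 to compound 3 is expected to be downward and beyond the scatter, of the size a 5.6-fold lower number from compound 2 to compound 3 (0.74 log units; beyond the scatter). Compound 3 is thus estimated at 45 ug/mL in this assay, within a range from 12 ug/mL to 140 ug/mL, the lower end still above the number of compound 1.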

Compound 3, solubility: 30 ug/mL
The estimate for compound 3 lay 1.5-fold (0.18 log units) above the measured number; low and high end bracket the measured number.
By their numbers in this assay, from the lowest: compounds 1 and 3 (each within the scatter of the next); then compound 2.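

In this assay, the saturated chain carbon bound to a double-bonded ring carbon now has its first reading for a change at one place: (oxolan-3-yl)oxy in place of piperazin-1-yl gives an 8.3-fold lower number from compound 2 to compound 3 (0.92 log units; beyond the scatter). The step shows that the number at this place depends on which group is held there, even though both groups are counted with the same heavy atoms and the same hydrogen-bond acceptors; they differ in ring size, in nitrogen against oxygen, and in the hydrogen-bond donor that only piperazin-1-yl carries. Nothing measured here separates these differences or gives a reason for the step.

On these data alone, with only these two groups at this place, it remains open which of those differences goes with the step, and whether the same change would give a step of similar size on another member of the series. Morpholin-4-yl, a six-membered ring holding one nitrogen and one oxygen, and a simple dimethylamino group on the same chain carbon would each bear on that question.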